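Working notes on cytotoxicity across three compounds

The source may hold more compounds than are shown below. What is called first, only, known or untested is meant among the compounds shown, and "the series" means these compounds.

Compound 1 `O=C(c1ccc2c(c1)OCCO2)C1CCN(Cc2coc(-c3cccc(F)c3)n2)CC1` and compound 2 `O=C(c1ccc(F)c(F)c1)C1CCN(Cc2coc(-c3ccc(F)cc3)n2)CC1` have both been run in an ADME assay on HEK293 cells (Homo sapiens) for cytotoxicity, read by MTT assay, with a stated time of 36 h; a lower number here means a stronger inhibitor, a higher number a weaker inhibitor. In this assay compound 1 gives > 150 ug/mL, which is a limit of the assay and not a measured number. In this assay compound 2 gives > 150 ug/mL, again a limit rather than a number. Compound 2 thus stands where compound 1 also stands, at the edge of what this assay reports, and the two cannot be ordered (the limit of > 150 ug/mL in this assay, at which 2 of the 2 values shown sit). Compound 3 `COc1ccc(C(=O)C2CCN(Cc3coc(-c4ccc(F)cc4)n3)CC2)cc1` is not yet measured. It differs from compound 2 by 4-methoxyphenyl in place of 3,4-difluorophenyl on a carbonyl carbon whose other neighbour is a saturated ring carbon. For the measured compounds named here, no measured step between compounds exists, so the series gives no direction for this change. Compound 2 sits at the limit > 150 ug/mL in this assay. For compound 3 the expected step of a number no higher from compound 2 to compound 3 (the limit leaves the size open) is accordingly none beyond the scatter. Compound 3 is therefore estimated at 150 ug/mL, within 75 ug/mL to 300 ug/mL, most likely reported only as a limit once more.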

Compound 3, half-maximal inhibitory concentration: > 150 ug/mL
Compound 3: a limit, no number; the forecaster's own chance of this, stated with the estimate: 80%; the middle value sits exactly at the limit.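

No step from compound 2 to compound 3 can be read in this assay, as both results are limits and not numbers: the limit of > 150 ug/mL in this assay, at which 3 of the 3 values shown sit.

The compounds shown leave open where any of the three would give a number in this assay, and whether swapping 3,4-difluorophenyl for 4-methoxyphenyl changes it.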